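The compounds below may be only part of what the source reports. "The series", "measured", "known", "first", "only" and "open" are said of these compounds alone.

Measured so far in an ADME assay on microsomes (Rattus norvegicus) for metabolic stability; on this read-out higher numbers stand for a longer-lived compound and lower numbers for a shorter-lived compound:
compound 1 `O=C(C1CCN(c2ccccc2)CC1)N1N=CCC1c1ccccc1`: 0.25 h
compound 2 `O=C(c1cocn1)N1CCC(C(=O)N2N=CCC2c2ccccc2)CC1`: 0.533 h

Of the two, compound 2 holds the higher number, at 0.533 h. Compound 3 `O=C(c1cc[nH]n1)N1CCC(C(=O)N2N=CCC2c2ccccc2)CC1` keeps all of compound 2 except one group: 1H-pyrazol-3-yl in place of 1,3-oxazol-4-yl on a carbonyl carbon. In words, 1H-pyrazol-3-yl stands in place of 1,3-oxazol-4-yl on a carbonyl carbon, and each is a five-membered aromatic ring with 2 hetero atoms. Going by the values given here, the only measured step that touches this group is a 2.1-fold higher number from compound 1 to compound 2 (0.33 log units; beyond the scatter). That modest step brought the (1,3-oxazol-4-yl)carbonyl in place of phenyl, so it shows what adding the group did, not what exchanging its ring does. Among the compounds with values here, no measured pair shows this exchange, so no clear change beyond the scatter is expected in this assay. The expected step is a 1.2-fold lower number from compound 2 to compound 3 (0.07 log units; within the scatter). The estimate for compound 3 is 0.45 h, with an expected range of 0.2 h to 1 h.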

Compound 3, half-life: 0.317 h
Compound 3: middle estimate off by 1.4-fold (0.15 log units), on the high side; the range from low to high includes it.
By their numbers in this assay, from the lowest: compounds 1, 3 and 2 (each within the scatter of the next, the first and the last beyond it).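

In this assay, exchanging one five-membered aromatic ring with 2 hetero atoms for another on the carbonyl carbon gives a 1.7-fold lower number from compound 2 to compound 3 (0.23 log units; within the scatter), so this direct swap cannot be told apart from the normal variation between repeat measurements. Placing (1H-pyrazol-3-yl)carbonyl where phenyl stood gives a 1.3-fold higher number from compound 1 to compound 3 (0.10 log units; within the scatter), whereas the (1,3-oxazol-4-yl)carbonyl group gave a 2.1-fold higher number from compound 1 to compound 2 (0.33 log units; beyond the scatter), so the clear step seen earlier does not carry over to this closely related group. No supporting measurement is available to explain these numbers.

The compounds shown leave open what a pyridine ring or a simple methyl group on this carbonyl carbon would do to the half-life. On these data alone, what a fluorine atom on the shared core would do also remains open.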